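Nitro for methoxy on the pyrazoline aryl ring

The compounds below may be only part of what the source reports. "The series", "measured", "known", "first", "only" and "open" are said of these compounds alone.

Within the data shown here, compound 2 `COc1ccc(C2CC(c3ccc(NC(=O)c4cc(Cl)ccc4OC)cc3)=NN2)cc1` is one of two compounds measured in a functional assay on the whole organism (plasma, strain albino) for inhibition, with Rattus norvegicus as the target, with stated times of 1 h and 4 h, at a dose of 50 mg/kg by the oral route; on this read-out lower numbers stand for a weaker effect and higher numbers for a stronger effect at the one dose given; in that assay compound 2 gives 83%. Compound 1 `COc1ccc(Cl)cc1C(=O)Nc1ccc(C2=NN(c3ccccc3)C(c3ccc([N+](=O)[O-])cc3)C2)cc1`, which carries a nitro group and an additional phenyl on the ring nitrogen, gives 85.3% in this assay. The two numbers lie within the usual scatter of each other, so nothing separates compound 2 from compound 1 on these data.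

Compound 3 `COc1ccc(Cl)cc1C(=O)Nc1ccc(C2=NNC(c3ccc([N+](=O)[O-])cc3)C2)cc1` has not been measured. It differs from compound 2 in one place: nitro in place of methoxy on an aromatic carbon. Among the measured compounds shown here, no step between two measured compounds isolates this change, so the expected size of the step rests only on the near-equal numbers already at hand. The expected change in this assay is none beyond the scatter, because compound 1, which also bears the nitro group, gives 85.3%. For compound 3 the estimated inhibition is 84%, with a range from 70% to 93%. That estimate corresponds to an expected step of a number 1 percentage points higher from compound 2 to compound 3 (within the scatter).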

Compound 3, a percentage reported as inhibition, in the whole organism at one dose (the size of the read-out at that dose, not a potency): 86.3%
For compound 3 the middle estimate is 2.3 percentage points below the measured one; measured number inside the range.
By their numbers in this assay, from the lowest: compounds 2, 1 and 3 (each within the scatter of the next).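

In this assay, among these compounds, the first step that isolates 4-methoxyphenyl to 4-nitrophenyl, on an aromatic carbon para to a large group, reads a number 3.3 percentage points higher from compound 2 to compound 3 (within the scatter), so the read-out does not tell these two groups apart at this position when the amine nitrogen in the ring carries hydrogen. With the nitro group held, hydrogen in place of phenyl on that nitrogen gives a number 1 percentage points higher from compound 1 to compound 3 (within the scatter), so that change is not told apart either. Nothing at hand bears on the reason for either reading.

As far as these compounds go, a read-out at one dose is not a potency, so any difference between these compounds at other doses remains open. Also open, from the compounds shown here alone, is whether an amine or a carboxylic acid at this aromatic position, or a longer chain on the ring nitrogen, would stay within the scatter of compound 3 in this assay.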